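Swapping ethylsulfanyl for trifluoroethoxy on the shared core

The source may hold more compounds than are shown below. What is called first, only, known or untested is meant among the compounds shown, and "the series" means these compounds.

Measured in a functional assay on HeLa cells (Homo sapiens) for antiproliferative activity, read by CCK-8 assay, with a stated time of 72 h; a higher number here means a weaker inhibitor, a lower number a stronger inhibitor:
- compound 1 `COc1ccc(-c2cncnc2-c2cc(OC)c(OC)c(OC)c2)cc1`: 1140 nM
- compound 2 `CCSc1ccc(-c2cncnc2-c2cc(OC)c(OC)c(OC)c2)cc1`: 370 nM

Of these two compounds, compound 2 has the lower number, 370 nM, and so is the stronger inhibitor in this assay. Compound 3 `COc1cc(-c2ncncc2-c2ccc(OCC(F)(F)F)cc2)cc(OC)c1OC` keeps the shared core but has 2,2,2-trifluoroethoxy in place of ethylsulfanyl on an aromatic carbon, para to a large group (2,2,2-trifluoroethoxy in place of ethylsulfanyl on an aromatic carbon). Going by the values given here, only one measured step bears on this change: a 3.1-fold lower number from compound 1 to compound 2 (0.49 log units; beyond the scatter), a modest gain when ethylsulfanyl replaced methoxy. Compound 3 gives up that ethylsulfanyl and again has an oxygen-linked group, though not the methoxy of compound 1, so only part of that gain is expected to be lost. The expected change in this assay is a 1.6-fold higher number from compound 2 to compound 3 (0.21 log units; within the scatter), a small step toward a higher number. The estimated value for compound 3 is 600 nM, with an expected range of 220 nM to 1500 nM.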

Compound 3, half-maximal inhibitory concentration: 10200 nM
Compound 3: middle estimate off by 17-fold (1.23 log units), on the low side; the whole stated range lies below it.
By their numbers in this assay, from the lowest: compound 2; then compound 1; then compound 3.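

In this assay, going by these compounds alone, the change from ethylsulfanyl to 2,2,2-trifluoroethoxy gives a 28-fold higher number from compound 2 to compound 3 (1.44 log units; beyond the scatter), so this position, on an aromatic carbon para to a large group, is far more sensitive to the choice of group than the single earlier step showed. The oxygen link alone does not set the level here: with an 8.9-fold higher number from compound 1 to compound 3 (0.95 log units; beyond the scatter), placing trifluoromethyl on the chain carbon bound to oxygen separates two oxygen-linked compounds, and compound 3 ends up weaker than both earlier compounds. Nothing available explains this loss.

The compounds shown leave open whether a plain ethoxy group would stand nearer to compound 1 or to compound 3. They also leave open whether 2,2,2-trifluoroethylsulfanyl would keep the level of compound 2 or fall toward that of compound 3.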